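The source may hold more compounds than are shown below. What is called first, only, known or untested is meant among the compounds shown, and "the series" means these compounds.

Of the compounds shown here, two built on a shared core have so far been tested in a functional assay on MCF7 cells (Homo sapiens) for inhibition, read by MTT assay, with a stated time of 72 h; on this read-out higher numbers stand for weaker inhibition and lower numbers for stronger inhibition. For the measured compounds named here, compound 1 `CC(C)c1ccc(-c2nc(SCc3cn(CC(=O)NC(=O)Nc4ccccn4)nn3)nc(Nc3cccc(C(F)(F)F)c3)c2C#N)cc1` gives 8620 nM, and compound 2 `CC(C)c1ccc(-c2nc(SCc3cn(CC(=O)NC(=O)Nc4ccccn4)nn3)nc(Nc3cccc([N+](=O)[O-])c3)c2C#N)cc1` gives 25900 nM, the higher of the two numbers, with compound 1 as its only neighbour. Going by the values given here, the single measured step, a 3.0-fold higher number from compound 1 to compound 2 (0.48 log units; beyond the scatter), swapped a group on the same aromatic ring attached to the ring nitrogen. Compound 3 `Cc1ccc(Nc2nc(SCc3cn(CC(=O)NC(=O)Nc4ccccn4)nn3)nc(-c3ccc(C(C)C)cc3)c2C#N)cc1` differs from compound 2 by 4-methylphenyl in place of 3-nitrophenyl on a nitrogen on an aromatic ring. Among the compounds with values here, no measured step tests this exact exchange; the one step available shows only that a change of group there shifts the number modestly. Compound 3 is therefore expected to show a 2.4-fold lower number from compound 2 to compound 3 (0.37 log units; beyond the scatter), with an estimated 11000 nM spanning 4000 nM to 30000 nM.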

Compound 3, half-maximal inhibitory concentration: > 64000 nM
Compound 3: a limit, no number (the forecaster's own chance of this, stated with the estimate: 5%); middle value at least 5.8-fold (0.76 log units) from the limit.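

In this assay compound 3 gives > 64000 nM, which is a limit and not a number: the limit of > 64000 nM in this assay, at which 1 of the 3 values shown sits. Placing 4-methylphenyl on this nitrogen gives an at least 2.4-fold higher number from compound 2 to compound 3 (0.39 log units; beyond the scatter), and an at least 7.4-fold higher number from compound 1 to compound 3 (0.87 log units; beyond the scatter). For the compounds shown here, the position therefore tolerates less than the single earlier step suggested, since this aryl exchange moves the number upward past both earlier compounds, and its true size stays unknown. As far as these compounds go, what an amine, a methoxy group or a chlorine on this phenyl ring would do remains open. Also open, from the compounds shown here alone, is whether the methyl group itself or its place on the ring drives the loss.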